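Substituent swap on the outer ring of a diarylalkyne series

A few compounds are considered here, and "the series" means these few. Any claim that something is new, unique, unknown or untested is made for them only; others in the source may bear on it.

Measured so far:
compound 1 `OCCCCC#Cc1ccccc1C#Cc1ccccc1`, 21100 nM
compound 2 `CSc1ccccc1C#Cc1ccccc1C#CCCCCO`, 6100 nM

In a functional assay on K562 cells (Homo sapiens) for cytotoxicity (a lower number here means a stronger inhibitor of growth, a higher number a weaker inhibitor of growth), compound 1 gives 21100 nM and compound 2 gives 6100 nM. Compound 2 stands lowest of the two numbers; its nearest neighbour is compound 1, reached by a 3.5-fold lower number from compound 1 to compound 2 (0.54 log units; beyond the scatter). Compound 3 `OCCCCC#Cc1ccccc1C#Cc1ccccc1C(F)(F)F` differs from compound 2 by trifluoromethyl in place of methylsulfanyl on an aromatic carbon. Among the compounds with values here, no measured step exchanges these two groups. Within the data shown here, the only step bearing on this position is a 3.5-fold lower number from compound 1 to compound 2 (0.54 log units; beyond the scatter), which shows that a group there moves this assay by a modest amount. A step of about that size, back toward compound 1, is expected: a 1.6-fold higher number from compound 2 to compound 3 (0.21 log units; within the scatter). Compound 3 is expected to give 10000 nM in this assay, within 3000 nM to 30000 nM.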

Compound 3, concentration for 50% growth inhibition: 1100 nM
Compound 3: middle estimate off by 9.1-fold (0.96 log units), on the high side; the measured number lies below the stated range.
By their numbers in this assay, from the lowest: compound 3; then compound 2; then compound 1.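

In this assay the identity of the group on this aromatic carbon matters, not merely its presence: trifluoromethyl in place of methylsulfanyl gives a 5.5-fold lower number from compound 2 to compound 3 (0.74 log units; beyond the scatter), and trifluoromethyl in place of hydrogen gives a 19-fold lower number from compound 1 to compound 3 (1.28 log units; beyond the scatter), a large step where methylsulfanyl gave a modest one. Nothing available explains the difference between these two groups. The compounds shown leave open whether a nitrile, an amine or a carboxylic acid on this aromatic carbon would match trifluoromethyl or fall nearer methylsulfanyl or hydrogen.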